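Benzothiophene carbonyl in place of difluorophenyl carbonyl

The compounds below may be only part of what the source reports. "The series", "measured", "known", "first", "only" and "open" are said of these compounds alone.

Compound 2, `O=C1c2ccccc2C(=O)N1CCOC(=S)N(C(=O)c1cc(F)ccc1F)c1ccc(Cl)cc1`, gives in an ADME assay on MT4 cells (Homo sapiens) for cytotoxicity, read by MTT assay (on this read-out lower numbers stand for higher toxicity in this test and higher numbers for lower toxicity in this test), a half-maximal cytotoxic concentration of 54000 nM. Compound 1, `Cc1ccc(N(C(=O)c2cccc(C)c2)C(=S)OCCN2C(=O)c3ccccc3C2=O)cc1`, reaches only the limit of the test in this assay, reported as > 100000 nM. For the measured compounds named here, compound 2 thus holds the only numerical value in this assay, while the other value is a limit (the limit of > 100000 nM in this assay, at which 1 of the 2 values shown sits), so no measured step between compounds is available for comparison.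

Compound 3, `O=C1c2ccccc2C(=O)N1CCOC(=S)N(C(=O)c1cc2ccccc2s1)c1ccc(Cl)cc1`, differs from compound 2 in a single place: 1-benzothiophen-2-yl in place of 2,5-difluorophenyl on a carbonyl carbon. With nothing measured to calibrate this change, the expectation rests on compound 2 alone. The step is expected to be modest, tending toward somewhat higher toxicity in this assay, or to stay within the scatter, with an estimated step of a 1.4-fold lower number from compound 2 to compound 3 (0.13 log units; within the scatter).

Compound 3 is therefore estimated at 40000 nM in this assay, with a likely range from 15000 nM to 100000 nM.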

Compound 3, half-maximal cytotoxic concentration: 56000 nM
Compound 3: middle estimate off by 1.4-fold (0.15 log units), on the low side, and the stated range covers the measured number.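

For the compounds shown here, the replacement of 2,5-difluorophenyl by 1-benzothiophen-2-yl on the carbonyl carbon gives a 1.0-fold higher number from compound 2 to compound 3 (0.02 log units; within the scatter) in this assay, the only step that can be read at this place. One five-membered and one six-membered aromatic ring thus stand in place of a single six-membered one, and sulfur in place of two fluorine atoms, with the read-out staying within the scatter. Nothing measured among the compounds shown accounts for this result.

Going by these compounds alone, compound 1 carries a limit and differs from compound 2 in more than one place, so no step to it can be read. Going by these compounds, whether a piperidine, or a phenyl carrying a carboxylic acid, on this carbonyl carbon would also leave the number within the scatter remains open.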